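Trifluoromethyl in place of methyl: the step to compound 4

The source may hold more compounds than are shown below. What is called first, only, known or untested is meant among the compounds shown, and "the series" means these compounds.

In a physicochemical assay for pharmacokinetics (on this read-out lower numbers stand for a shorter-lived compound and higher numbers for a longer-lived compound), compound 3 `Cc1ccccc1CNC(=O)N1C(=O)c2ccccc2S1(=O)=O` gives 0.792 h, compound 1 `O=C(NCc1ccccc1F)N1C(=O)c2ccccc2S1(=O)=O` gives 0.598 h and compound 2 `O=C(NCc1ccccc1Cl)N1C(=O)c2ccccc2S1(=O)=O` gives 0.42 h. The steps of a 1.3-fold higher number from compound 1 to compound 3 (0.12 log units; within the scatter) and a 1.9-fold higher number from compound 2 to compound 3 (0.28 log units; within the scatter) both lie within the scatter, so the numbers do not separate compound 3 from the other two.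

Compound 4 `O=C(NCc1ccccc1C(F)(F)F)N1C(=O)c2ccccc2S1(=O)=O` carries trifluoromethyl in place of methyl on an aromatic carbon, ortho to a large group: trifluoromethyl in place of methyl on an aromatic carbon. For the measured compounds named here, no measured pair covers this exchange directly. The closest evidence is the set of exchanges on that same aromatic carbon: the two steps above, together with a 1.4-fold lower number from compound 1 to compound 2 (0.15 log units; within the scatter), which is also within the scatter. None of the three leaves the scatter in this assay, so a step beyond it is not expected here, and the direction is only weakly defined. The estimated step is a 1.4-fold lower number from compound 3 to compound 4 (0.14 log units; within the scatter), which is expected to stay within the scatter. For compound 4 the expected value is 0.58 h, with an estimated range of 0.3 h to 1.1 h.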

Compound 4, half-life: 0.187 h
Estimate against measurement, compound 4: 3.1-fold (0.49 log units) above; the whole stated range lies above it.
By their numbers in this assay, from the lowest: compound 4; then compounds 2, 1 and 3 (each within the scatter of the next).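

In this assay, for the compounds shown here, trifluoromethyl is the first group on this aromatic carbon, ortho to a large group, to stand apart from the others: the series shows a 4.2-fold lower number from compound 3 to compound 4 (0.63 log units; beyond the scatter) together with a 3.2-fold lower number from compound 1 to compound 4 (0.50 log units; beyond the scatter) and a 2.2-fold lower number from compound 2 to compound 4 (0.35 log units; beyond the scatter). Methyl, fluoro and chloro stayed within the scatter of one another, so the position looked insensitive until this exchange. Compound 4 is now the shortest-lived of the four, and nothing available here explains the drop.

From the compounds shown here alone, it remains open whether the shorter half-life is particular to trifluoromethyl or would also appear with a methoxy group or a nitrile on the same carbon. Equally open, going by these compounds, is whether trifluoromethyl would have the same effect at another carbon of this ring.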